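A few compounds are considered here, and "the series" means these few. Any claim that something is new, unique, unknown or untested is made for them only; others in the source may bear on it.

Working notes on the series. In an assay on isolated protein for inhibition of histone deacetylase 8 (Homo sapiens), with a stated time of 1 h (on this read-out lower numbers stand for stronger inhibition and higher numbers for weaker inhibition), compound 1 `O=C(COc1ccc2cc(/C=C3/SC(=O)NC3=O)ccc2c1)Nc1ccc(F)cc1` gives 6600 nM and compound 2 `Cc1cccc2sc(NC(=O)COc3ccc4cc(/C=C5/SC(=O)NC5=O)ccc4c3)nc12` gives 5800 nM; the step of a 1.1-fold lower number from compound 1 to compound 2 (0.06 log units; within the scatter) lies within the scatter, so the two sit together. Compound 3 `O=C(COc1ccc2cc(/C=C3/SC(=O)NC3=O)ccc2c1)Nc1c(F)cc(F)cc1Br` gives only a limit, > 50000 nM, in this assay (the limit of > 50000 nM in this assay, at which 1 of the 3 values shown sits). Against that limit the steps of an at least 7.5-fold higher number from compound 1 to compound 3 (0.87 log units; beyond the scatter) and an at least 8.6-fold higher number from compound 2 to compound 3 (0.93 log units; beyond the scatter) both run beyond the scatter, so compound 3 stands apart from the other two at the weak end of what has been measured.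

Compound 4 `Cc1ccc(NC(=O)COc2ccc3cc(/C=C4/SC(=O)NC4=O)ccc3c2)cc1Cl` differs from compound 3 in one place: 3-chloro-4-methylphenyl in place of 2-bromo-4,6-difluorophenyl on an amide-type nitrogen. The change removes the group that, in the steps from compound 1 and from compound 2 to compound 3, went with the move to the limit, and puts in another six-membered aromatic ring of carbon only. The bearing steps are those two, each at least modest; the new group is not itself among the measured ones, so the size is uncertain. A return toward the region of compound 1 and compound 2 is expected, the expected step being an at least 6.2-fold lower number from compound 3 to compound 4 (0.79 log units; beyond the scatter). Compound 4 is thus estimated at 8000 nM, with a range from 2500 nM to 30000 nM.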

Compound 4, half-maximal inhibitory concentration: > 50000 nM
Compound 4 gave a limit, no number (the forecaster's own chance of this, stated with the estimate: 15%); at least 6.2-fold (0.79 log units) between middle value and limit.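

In this assay compound 4 gives > 50000 nM, which is a limit and not a number: the limit of > 50000 nM in this assay, at which 2 of the 4 values shown sit. The step between compound 3 and compound 4 cannot be read, as both values are limits. Both an at least 7.5-fold higher number from compound 1 to compound 4 (0.87 log units; beyond the scatter) and an at least 8.6-fold higher number from compound 2 to compound 4 (0.93 log units; beyond the scatter) run beyond the scatter, so the move to the limit on this amide-type nitrogen is not confined to 2-bromo-4,6-difluorophenyl: 3-chloro-4-methylphenyl, with no bromine or fluorine, goes with it too, while 4-fluorophenyl and 4-methyl-1,3-benzothiazol-2-yl stay on the measurable side.

Going by these compounds, whether the chlorine or the methyl of 3-chloro-4-methylphenyl goes with the limit stays open. Also open, on these data alone, is whether an aromatic ring carrying an amine or a carboxylic acid on this nitrogen would give a number rather than a limit.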